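This account rests on a few compounds, and the source may have more. Where it says the series, first, only, none or still open, it means among the compounds named here.

- compound 1 `CC1(C)CCc2cc(C(=O)/C=C/c3ccc(OCc4cn(-c5ccc(Br)cc5)nn4)cc3)c(O)cc2O1`: 80000 nM
- compound 2 `Cc1c(-n2cc(COc3ccc(/C=C/C(=O)c4ccc5c(c4O)CCC(C)(C)O5)cc3)nn2)cccc1[N+](=O)[O-]`: "not active" (no number reported)

Going by the values given here, in a functional assay on A549 cells (Homo sapiens) for antiproliferative activity, read by MTT assay (a higher number here means a weaker inhibitor, a lower number a stronger inhibitor), compound 1 gives 80000 nM, the only number available so far. Compound 2 is reported as "not active" (no number reported), without a number. Compound 3 `CC1(C)CCc2cc(C(=O)/C=C/c3ccc(OCc4cn(Cc5ccc([N+](=O)[O-])cc5)nn4)cc3)c(O)cc2O1` has not yet been measured. It differs from compound 1 by 4-nitrobenzyl in place of 4-bromophenyl on an aromatic nitrogen, with 4-nitrobenzyl in place of 4-bromophenyl on an aromatic nitrogen. Among the compounds with values here, no measured pair shows the size of such a change, so no step beyond the scatter is expected in this assay, in either direction. The estimated change is a 1.1-fold lower number from compound 1 to compound 3 (0.06 log units; within the scatter). Compound 3 is expected at 70000 nM, within an estimated range of 25000 nM to 180000 nM.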

Compound 3, half-maximal inhibitory concentration: 35800 nM
Compound 3: middle estimate off by 2.0-fold (0.29 log units), on the high side; the measured number falls inside the stated range.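

In this assay, 4-nitrobenzyl in place of 4-bromophenyl on the aromatic nitrogen gives a 2.2-fold lower number from compound 1 to compound 3 (0.35 log units; beyond the scatter), a modest step. Going by these compounds alone, this is the first measured sign that the group on this nitrogen can move the number beyond the scatter, although compound 3 still stands at 35800 nM. Nothing available explains the step. The compounds shown leave open whether it belongs to the extra carbon of the benzyl group or to the exchange of bromine for nitro. A 4-bromobenzyl or a 4-nitrophenyl group on this nitrogen would separate the two.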